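Methyl in place of chloro on compound 1

The source may hold more compounds than are shown below. What is called first, only, known or untested is meant among the compounds shown, and "the series" means these compounds.

In a functional assay on KYSE-450 cells (Homo sapiens) for inhibition, read by MTT assay, with a stated time of 48 h (on this read-out lower numbers stand for stronger inhibition and higher numbers for weaker inhibition), compound 1 (`COc1ccc(CNc2cc(OC)c(OC)c(OC)c2)cc1Cl`) gives 47800 nM and compound 2 (`C/C=C/C(=O)N(Cc1ccc(OC)c(OC)c1)c1cc(OC)c(OC)c(OC)c1`) gives 39100 nM as its value, and these two numbers lie within the usual scatter of each other. Compound 3 (`COc1ccc(CNc2cc(OC)c(OC)c(OC)c2)cc1C`) keeps the core of compound 1 and differs in one place (methyl in place of chloro on an aromatic carbon), with methyl in place of chloro on an aromatic carbon. Among the compounds with values here, no measured pair shows this exchange. The estimated 1.1-fold lower number from compound 1 to compound 3 (0.03 log units; within the scatter) in this assay is expected to stay within the scatter, in neither direction. Compound 3 is expected at 45000 nM (range 18000 nM to 100000 nM).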

Compound 3, half-maximal inhibitory concentration: 73800 nM
The estimate for compound 3 lay 1.6-fold (0.21 log units) below the measured number, within the range that was stated.
By their numbers in this assay, from the lowest: compounds 2, 1 and 3 (each within the scatter of the next).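

Within the data shown here, on the aromatic carbon ortho to a methoxy group, methyl in place of chloro gives the first direct reading of this exchange: a 1.5-fold higher number from compound 1 to compound 3 (0.19 log units; within the scatter) in this assay. At this position and in this assay, the two groups cannot be told apart, although the exchange removes the only chlorine. No available measurement offers a reason for this result.

On these data alone, it remains open whether an amine, a hydroxyl or a carboxylic acid on this aromatic carbon would give a number beyond the scatter of compound 1.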